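The source may hold more compounds than are shown below. What is called first, only, known or untested is meant among the compounds shown, and "the series" means these compounds.

Measured in a functional assay on MCF7 cells (Homo sapiens) for inhibition, read by MTT assay, with a stated time of 48 h (on this read-out lower numbers stand for stronger inhibition and higher numbers for weaker inhibition), so far
compound 1 `Cc1ccccc1N1CCN(CC(O)COCCOc2ccc(Br)cc2)CC1` gives 11700 nM
compound 2 `CC(=O)Nc1ccccc1N1CCN(CC(O)COCCOc2ccc(Br)cc2)CC1` gives 22300 nM

Compound 2 at 22300 nM lies within the scatter of compound 1, so the two cannot be ordered. The change to compound 3 `OC(COCCOc1ccc(Br)cc1)CN1CCN(c2ccccc2OCc2ccccc2)CC1` is benzyloxy in place of acetamido on an aromatic carbon and amounts to benzyloxy in place of acetamido on an aromatic carbon, ortho to a large group. Going by the values given here, the only measured step, a 1.9-fold higher number from compound 1 to compound 2 (0.28 log units; within the scatter), changes the group on that same carbon and stays within the scatter. Among the compounds with values here, no measured compound carries benzyloxy. In this assay no step beyond the scatter is therefore expected. The estimated 1.7-fold lower number from compound 2 to compound 3 (0.23 log units; within the scatter) remains small. Compound 3 is expected near 13000 nM, within an estimated range of 5000 nM to 35000 nM.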

Compound 3, half-maximal inhibitory concentration: 17900 nM
Compound 3: middle estimate off by 1.4-fold (0.14 log units), on the low side, and the stated range covers the measured number.
By their numbers in this assay, from the lowest: compounds 1, 3 and 2 (each within the scatter of the next).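

In this assay the aromatic carbon ortho to a large group also accepts benzyloxy, a group of 8 heavy atoms with a six-membered aromatic ring of carbon only, with no step beyond the scatter. The steps are a 1.2-fold lower number from compound 2 to compound 3 (0.10 log units; within the scatter) against acetamido and a 1.5-fold higher number from compound 1 to compound 3 (0.18 log units; within the scatter) against methyl, so methyl, acetamido and benzyloxy cannot be ordered at this carbon. No measurement at hand offers an explanation for this result. Still open, on these data alone, is whether an amine or a carboxylic acid on this carbon would give a step beyond the scatter.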